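A few compounds are considered here, and "the series" means these few. Any claim that something is new, unique, unknown or untested is made for them only; others in the source may bear on it.

Of the compounds shown here, three built on one shared core have been measured in an ADME assay on PC-3 cells (Homo sapiens) for cytotoxicity, read by WST assay, tested at 100 uM; a higher number here means more inhibition at the concentration tested (going by the name of the read-out), a lower number less inhibition. In that assay compound 1 `O=C(Nc1cccc([N+](=O)[O-])c1)C1CCCN(C(=O)c2cc(C(F)(F)F)cc(C(F)(F)F)c2)C1` gives 9%. Compound 2 `CSc1cccc(NC(=O)C2CCCN(C(=O)c3cc(C(F)(F)F)cc(C(F)(F)F)c3)C2)c1` gives 0%, and compound 3 `CCc1cccc(NC(=O)C2CCCN(C(=O)c3cc(C(F)(F)F)cc(C(F)(F)F)c3)C2)c1` gives 0%. Compound 3 thus stands level with compound 2 at the digits reported, the two together forming the lowest of the three numbers; its nearest neighbour is compound 2 and its furthest is compound 1, and the step of a number 9 percentage points lower from compound 1 to compound 3 (within the scatter) stays within the scatter.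

Compound 4 `CC(=O)c1cccc(NC(=O)C2CCCN(C(=O)c3cc(C(F)(F)F)cc(C(F)(F)F)c3)C2)c1` is the next member of the series. It differs from compound 3 by acetyl in place of ethyl on an aromatic carbon.

For the measured compounds named here, three measured steps bear on this change, each a single replacement on an aromatic carbon: the step from compound 1 to compound 3 already named, together with a number 9 percentage points lower from compound 1 to compound 2 (within the scatter) and no change at the digits printed from compound 2 to compound 3 (within the scatter). None of them moves the read-out beyond the usual scatter, and nothing among these compounds suggests that acetyl in that place would act differently from nitro, methylsulfanyl or ethyl. The step of a number 3 percentage points higher from compound 3 to compound 4 (within the scatter) is therefore expected to remain within the scatter. For compound 4 the estimate in this assay is 3%, with a range from -7% to 15%.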

Compound 4, a percentage reported as inhibition, at one concentration (the size of the read-out at that concentration, not a potency): 0%
The estimate for compound 4 lay 3 percentage points above the measured number; low and high end bracket the measured number.
By their numbers in this assay, from the lowest: compounds 2, 3, 4 and 1 (each within the scatter of the next).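

The aromatic carbon meta to a large group now carries a fourth group, acetyl, which brings a carbonyl and a hydrogen-bond acceptor that ethyl lacks, and in this assay this exchange gives no change at the digits printed from compound 3 to compound 4 (within the scatter) in a series where the earlier compounds had shown only three groups at this place. Set against the other two groups, the same change of group gives no change at the digits printed from compound 2 to compound 4 (within the scatter) and a number 9 percentage points lower from compound 1 to compound 4 (within the scatter) as well, so nitro, methylsulfanyl, ethyl and acetyl all lie within the scatter of one another here, and the flat picture now holds for all four compounds shown. Nothing shown here gives any measured property that would account for this flat read-out at this place.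

Still open, on these data alone, is whether an amine or a carboxylic acid on this aromatic carbon, or a chain longer than ethyl, would move the number in this assay beyond the scatter. Also open, as far as these compounds go, is whether replacing either trifluoromethyl group on the shared core would leave this read-out as flat as the changes at this one place have done.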